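Swapping the anilino arm for a 4-phenylpiperidine

The source may report more compounds than this note shows. Statements on the series, on what has been measured and on what is new or still open speak of the compounds shown alone.

Compound 1 `Cc1ccc(Nc2nc(C(F)(F)F)ccc2CNC(=O)C(C)c2ccc(NS(C)(=O)=O)c(F)c2)cc1C` carries an arylamino group on a pyridine core, and in a functional assay on CHO-K1 cells for antagonist activity at transient receptor potential cation channel subfamily V member 1 (Homo sapiens), read by FLIPR (a lower number here means a stronger inhibitor, a higher number a weaker inhibitor), compound 1 gives 1160 nM; this is the only number shown, so it stands alone. Compound 2 `CC(C(=O)NCc1ccc(C(F)(F)F)nc1NCc1cccnc1)c1ccc(NS(C)(=O)=O)c(F)c1`, which bears a different arm at that position, is reported in this assay as "not active" (no number reported). Compound 3 `CC(C(=O)NCc1ccc(C(F)(F)F)nc1N1CCC(c2ccccc2)CC1)c1ccc(NS(C)(=O)=O)c(F)c1` is not yet measured. It differs from compound 1 in one place: 4-phenylpiperidin-1-yl in place of (3,4-dimethylphenyl)amino on an aromatic carbon. Within the data shown here, no measured pair isolates this change, so any forecast rests on compound 1 alone, with compound 2 warning that the arm matters. A modest loss beyond the scatter is expected, a 2.2-fold higher number from compound 1 to compound 3 (0.33 log units; beyond the scatter). Compound 3 is estimated at 2500 nM, within 600 nM to 10000 nM.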

Compound 3, half-maximal inhibitory concentration: 25 nM
The estimate for compound 3 lay 100-fold (2.00 log units) above the measured number; measured number below the stated range.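

This position responds strongly to the shape of its arm: in this assay, 4-phenylpiperidin-1-yl in place of (3,4-dimethylphenyl)amino gives a 46-fold lower number from compound 1 to compound 3 (1.67 log units; beyond the scatter) and turns a weak inhibitor into a strong one. The entering arm has no hydrogen-bond donor, so strong inhibition in compound 3 does not need a donor on this arm. Nothing measured here gives a reason for the gain. On these data alone, it remains open whether the piperidine ring alone would suffice, or whether the phenyl group is needed. A morpholine or a 4-benzylpiperidine at this position could help to separate these two parts.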